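This account rests on a few compounds, and the source may have more. Where it says the series, first, only, none or still open, it means among the compounds named here.

Measured so far, in an assay (Rattus norvegicus) for inhibition of Fatty-acid amide hydrolase 1 (Homo sapiens); on this read-out lower numbers stand for stronger inhibition and higher numbers for weaker inhibition:
- compound 1 `O=C(CCCCCCc1ccccc1)c1ncc(-c2ccccc2F)o1` gives 110 nM
- compound 2 `N#Cc1ccc(-c2cnc(C(=O)CCCCCCc3ccccc3)o2)cc1` gives 40 nM

Compound 1 holds the highest of these two numbers, so of the two it is the weaker inhibitor; its nearest neighbour is compound 2, and the step of a 2.8-fold lower number from compound 1 to compound 2 (0.44 log units; beyond the scatter) is modest but beyond the scatter. Both compounds share the same core and the same seven-carbon chain ending in a phenyl ring; they differ only in the aromatic ring attached to the core.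

Compound 3 `COc1ccnc(-c2cnc(C(=O)CCCCCCc3ccccc3)o2)c1` has not yet been measured in this assay. Relative to compound 1 it carries one change: 4-methoxypyridin-2-yl in place of 2-fluorophenyl on an aromatic carbon. Going by the values given here, the one measured step that bears on it is the exchange of the same 2-fluorophenyl for another six-membered aromatic ring, a 2.8-fold lower number from compound 1 to compound 2 (0.44 log units; beyond the scatter), which brought a modest gain in this assay. The change to a 4-methoxypyridin-2-yl is a different exchange at the same place, so only a loose parallel can be drawn. A step of similar or smaller size, toward a lower number, is therefore expected, a 1.8-fold lower number from compound 1 to compound 3 (0.26 log units; within the scatter). For compound 3 the estimate in this assay is 60 nM, with a range from 20 nM to 200 nM.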

Compound 3, inhibition constant: 0.8 nM
Compound 3: the middle estimate sits 75-fold (1.88 log units) above what was measured; measured number below the stated range.
By their numbers in this assay, from the lowest: compound 3; then compound 2; then compound 1.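

The earlier pair made this place look like one where exchanging one aromatic ring for another shifts the number only modestly in this assay. The new result shows that the group on this aromatic carbon, next to the ring oxygen, can shift it far more: there is a 140-fold lower number from compound 1 to compound 3 (2.14 log units; beyond the scatter) and a 50-fold lower number from compound 2 to compound 3 (1.70 log units; beyond the scatter), and both steps are large. What enters with 4-methoxypyridin-2-yl is a six-membered aromatic ring with 1 hetero atom and 2 hydrogen-bond acceptors, where 2-fluorophenyl has a ring of carbon only and 0 acceptors, but no measurement at hand explains the size of this gain.

The compounds shown leave open how much of the step belongs to the ring nitrogen and how much to the methoxy group, since both enter together in a single change. From the compounds shown here alone, a plain pyridin-2-yl and a 4-methoxyphenyl would separate the two, and it is equally open whether an amine or a carboxylic acid in place of the methoxy group would keep the number this low.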